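The source may report more compounds than this note shows. Statements on the series, on what has been measured and on what is new or still open speak of the compounds shown alone.

For the measured compounds named here, compound 3 `O=C(O)C[C@H](NC(=O)CN(c1nc(Cl)nc2[nH]cnc12)C1CC1)C(=O)O` is one of three compounds measured so far in a functional assay on the whole organism (Tail, strain ICR) with Mus musculus as the target, in the tail flick test, with a stated time of 150 min, at a dose of 25 umol/kg by the oral route (a higher number here means a stronger effect of the compound at the dose given, a lower number a weaker effect), where compound 3 gives 11.6%. Its two companions are compound 1 `C[C@H](NC(=O)CN(c1nc(Cl)nc2[nH]cnc12)C1CC1)C(=O)O`, which in this assay gives 14.7%, and compound 2 `CC(C)[C@H](NC(=O)CN(c1nc(Cl)nc2[nH]cnc12)C1CC1)C(=O)OCc1ccccc1`, which gives 17.9%. Both of these numbers sit within the scatter of the number for compound 3, so the three compounds cannot be told apart on this read-out. Going by the values given here, the one single-point step known so far, a carboxy in place of hydrogen on a saturated chain carbon, two bonds along the chain from an amide-type nitrogen and a carbonyl carbon, reads a number 3.1 percentage points lower from compound 1 to compound 3 (within the scatter).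

Compound 4 `CC(C)[C@H](NC(=O)CN(c1nc(Cl)nc2[nH]cnc12)C1CC1)C(=O)O` is the next compound to be tested. It differs from compound 3 as follows: isopropyl in place of carboxymethyl on a saturated chain carbon bound to an amide-type nitrogen and a carbonyl carbon. This is not the same change as the one already measured, though it touches the same region of the chain and removes the carboxymethyl group whose introduction, read the other way, gave a number 3.1 percentage points lower from compound 1 to compound 3 (within the scatter). Compound 2 carries the same isopropyl group but with a benzyl ester, so its value offers no direct comparison. With only a step within the scatter to go by, compound 4 is expected to give a number near that of compound 3, a step of a number 4.4 percentage points higher from compound 3 to compound 4 (within the scatter), estimated at 16% with a range from 8% to 25%.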

Compound 4, a percentage reported as activity, at one dose (the size of the read-out at that dose, not a potency): 7.86%
For compound 4 the middle estimate is 8.1 percentage points above the measured one; the whole stated range lies above it.
By their numbers in this assay, from the lowest: compounds 4, 3, 1 and 2 (each within the scatter of the next).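

For the compounds shown here, at the saturated chain carbon bound to an amide-type nitrogen and a carbonyl carbon, the earlier compounds offered only one step, and compound 4 adds two more: isopropyl in place of carboxymethyl gives a number 3.7 percentage points lower from compound 3 to compound 4 (within the scatter) in this assay and isopropyl in place of methyl gives a number 6.8 percentage points lower from compound 1 to compound 4 (within the scatter) on the same read-out, so methyl, carboxymethyl and isopropyl at this carbon cannot be told apart. Compound 4 also opens a second place to comparison, since hydrogen in place of benzyl on an oxygen next to a carbonyl group gives a number 10 percentage points lower from compound 2 to compound 4 (within the scatter) and thus the benzyl ester, like the side group, shows no change beyond the scatter. Nothing available explains these numbers.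

Going by these compounds, whether an amine, a longer chain or a phenyl ring at this carbon would give a number clearly apart from these four stays open. So does whether a methyl ester or an amide in place of the free carboxylic acid would separate from compound 4 in this assay at all.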